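Aryl swap on a quinoline tail, read in HepG2 cells

This account rests on a few compounds, and the source may have more. Where it says the series, first, only, none or still open, it means among the compounds named here.

Measured compounds:
compound 1 `COc1ccc(Oc2ccc3c(NCCCNCc4cccc(OC)c4O)ccnc3c2)cc1`, an ADME assay on HepG2 cells (Homo sapiens) for cytotoxicity, read by luminescence, CellTiter-Glo and ATP content, with a stated time of 72 h; a lower number here means that less compound is needed, a higher number that more compound is needed for the effect: 5500 nM
compound 2 `c1ccc(-c2ccc3c(NCCCNCc4ccco4)ccnc3c2)cc1`, this assay: 5920 nM
compound 3 `COc1cccc(CNCCCNc2ccnc3cc(-c4ccccc4)ccc23)c1O`, this assay: 3210 nM

The three measured compounds share a core and differ at two places. Compound 3 and compound 1 differ only at the aromatic carbon of the core, where the change is 4-methoxyphenoxy in place of phenyl on an aromatic carbon; the step is a 1.7-fold higher number from compound 3 to compound 1 (0.23 log units; within the scatter). Compound 3 and compound 2 differ only at the chain end, where the change is furan-2-yl in place of 2-hydroxy-3-methoxyphenyl on a saturated chain carbon bound to an amine nitrogen; the step is a 1.8-fold lower number from compound 2 to compound 3 (0.27 log units; within the scatter). Going by the values given here, all three values lie within the scatter of one another, so no compound can be set apart from the others on these data.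

Compound 4 `COc1ccc(Oc2ccc3c(NCCCNCc4ccco4)ccnc3c2)cc1` has not yet been measured in this assay. It differs from compound 2 by 4-methoxyphenoxy in place of phenyl on an aromatic carbon, which is the same change as that made from compound 3 to compound 1, at a place described in the same words. Among the compounds with values here, the one measured example of that change gave a step within the scatter, so compound 4 is expected to give a number close to that of compound 2, with the step estimated as a 1.4-fold higher number from compound 2 to compound 4 (0.13 log units; within the scatter), resting on the size of the step from compound 3 to compound 1 and on the single occurrence of the change. For compound 4 the expected value in this assay is 8000 nM, with a range from 4000 nM to 16000 nM.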

Compound 4, half-maximal effective concentration: 5300 nM
Beside the measured number, compound 4's estimate is 1.5-fold (0.18 log units) above it; the measured number falls inside the stated range.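

In this assay, going by these compounds alone, 4-methoxyphenoxy in place of phenyl on an aromatic carbon gave a 1.1-fold lower number from compound 2 to compound 4 (0.05 log units; within the scatter), and this step agrees with the one seen for the same change on the other core: the same change on two cores in this assay, a 1.7-fold higher number (0.23 log units; within the scatter) from compound 3 to compound 1 and a 1.1-fold lower number (0.05 log units; within the scatter) from compound 2 to compound 4, 1.9-fold (0.28 log units) apart, within the scatter of two such steps Likewise, furan-2-yl in place of 2-hydroxy-3-methoxyphenyl on a saturated chain carbon bound to an amine nitrogen gave a 1.0-fold lower number from compound 1 to compound 4 (0.02 log units; within the scatter), which agrees with the earlier step for that change: the same change on two cores in this assay, a 1.8-fold lower number (0.27 log units; within the scatter) from compound 2 to compound 3 and a 1.0-fold higher number (0.02 log units; within the scatter) from compound 4 to compound 1, 1.9-fold (0.28 log units) apart, within the scatter of two such steps Each change therefore carries from one core to the other with no difference that can be told from the scatter, but every step involved also lies within the scatter, so the agreement shows only that neither change moved the number measurably on these two cores, and it does not show that either change has a real effect of a shared size or that the result would hold on a further core.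

The compounds shown leave open whether any change at these two places can move the number beyond the scatter in this series. That question stands for an amine or a carboxylic acid in place of 4-methoxyphenoxy on the aromatic carbon, and for a longer chain in place of the present one.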